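Thiophene in Place of Hydroxyphenyl on a Hydroxamic Acid

This account rests on a few compounds, and the source may have more. Where it says the series, first, only, none or still open, it means among the compounds named here.

Compound 1, `O=C(NO)c1ccc(/C=C/c2ccnc(-c3ccccc3O)c2)cc1`, gives 1450 nM in a functional assay on HCT-116 cells (Homo sapiens) for antiproliferative activity, read by CellTiter-Glo, with a stated time of 72 h; on this read-out lower numbers stand for stronger inhibition and higher numbers for weaker inhibition.
Compound 2, `O=C(NO)c1ccc(/C=C/c2cccc(-c3cc(F)ccc3O)c2)cc1`, reaches only the assay limit of > 10000 nM.

Among the measured compounds shown here, compound 1 holds the only true number here; compound 2 sits at the limit of > 10000 nM in this assay, at which 1 of the 2 values shown sits, and no step between the two is counted. Compound 3, `O=C(NO)c1ccc(/C=C/c2ccnc(-c3ccsc3)c2)cc1`, differs from compound 1 by thiophen-3-yl in place of 2-hydroxyphenyl on an aromatic carbon. In this assay a modest weakening is expected, a step of a 2.4-fold higher number from compound 1 to compound 3 (0.38 log units; beyond the scatter) from the value of compound 1. Compound 3 is therefore estimated at 3500 nM, within a range of 1200 nM to 10000 nM.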

Compound 3, half-maximal inhibitory concentration: 1910 nM
Beside the measured number, compound 3's estimate is 1.8-fold (0.26 log units) above it; measured number inside the range.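

In this assay, putting thiophen-3-yl in place of 2-hydroxyphenyl on the aromatic carbon next to the ring nitrogen gives a 1.3-fold higher number from compound 1 to compound 3 (0.12 log units; within the scatter) and so no real change. In this pair, then, neither the hydrogen-bond donor of 2-hydroxyphenyl nor a six-membered ring is required at this position for this level of activity. No measurement shown explains this result.

On these data alone, whether an amine or a carboxylic acid on this carbon would keep the activity stays open. So does how a plain phenyl ring would compare.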